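The compounds below may be only part of what the source reports. "The series", "measured", "known", "first", "only" and "open" are said of these compounds alone.

In a functional assay on NIH3T3 cells (Mus musculus) for inhibition (a higher number here means that more compound is needed for the effect, a lower number that less compound is needed), compound 1 (`CSCC[C@H](NC(=O)c1ccc(/C=C/c2c[nH]cn2)cc1-c1ccccc1C)C(=O)O`) gives > 1000 nM, which is a limit and not a number. Compound 2 (`CSCC[C@H](NC(=O)c1ccc(/C=C/c2cnc3ccccc3c2)cc1-c1ccccc1C)C(=O)O`) gives > 1000 nM, also a limit. For the measured compounds named here, the one measured step, a step that the two limits leave unreadable from compound 1 to compound 2, has no readable size, and the evidence amounts to the limit of > 1000 nM in this assay, at which 2 of the 2 values shown sit. Compound 3 (`CSCC[C@H](NC(=O)c1ccc(C#Cc2cccnc2)cc1-c1ccccc1C)C(=O)O`) carries 2-(pyridin-3-yl)ethynyl in place of 2-(1H-imidazol-4-yl)ethenyl on an aromatic carbon. Going by the values given here, with no sized step to carry over, no change beyond the scatter is expected, in either direction, in this assay. The expected step that the limit leaves unreadable from compound 1 to compound 3 is an estimate only. Compound 3 is estimated at 2000 nM, with an expected range of 500 nM to 10000 nM.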

Compound 3, half-maximal effective concentration: 1000 nM
For compound 3 the middle estimate is 2.0-fold (0.30 log units) above the measured one, and the stated range covers the measured number.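

For the compounds shown here, at the place para to a large group, 2-(pyridin-3-yl)ethynyl gives the only value in this assay that is a number and not a limit: compound 3 gives 1000 nM. This is a number no higher from compound 1 to compound 3 (the limit leaves the size open), and likewise a number no higher from compound 2 to compound 3 (the limit leaves the size open). The size of neither step can be read, and the comparison stops at the limit: the limit of > 1000 nM in this assay, at which 2 of the 3 values shown sit. The change swaps the ring and the triple bond for the double bond together, so neither can be credited alone. Open, on these data alone, is how 2-(pyridin-3-yl)ethenyl would read, and how an amine on the pyridin-3-yl ring would read, in this assay.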